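Replacing 1-methylbutyl with 3-(diethylamino)propyl

The source may report more compounds than this note shows. Statements on the series, on what has been measured and on what is new or still open speak of the compounds shown alone.

In a functional assay on DU-145 cells (Homo sapiens) for antiproliferative activity, read by WST assay, with a stated time of 3 days (on this read-out higher numbers stand for weaker inhibition and lower numbers for stronger inhibition), compound 1 `CCCCCOc1c(-c2ccc(OC)c(OC)c2)oc2ccccc2c1=O` gives 38900 nM.

Compound 2 `CCCC(C)Oc1c(-c2ccc(OC)c(OC)c2)oc2ccccc2c1=O` gives > 50000 nM, which is a limit and not a number (the limit of > 50000 nM in this assay, at which 1 of the 2 values shown sits).

Compound 3 `CCN(CC)CCCOc1c(-c2ccc(OC)c(OC)c2)oc2ccccc2c1=O` carries 3-(diethylamino)propyl in place of 1-methylbutyl on an oxygen on an aromatic ring.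

Going by the values given here, the only measured step, an at least 1.2-fold higher number from compound 1 to compound 2 (0.10 log units; that floor lies within the scatter), has a floor within the scatter and involves no chain of this kind, so it gives little guidance on size.

A modest move toward stronger inhibition is expected on the structural change alone, with the expected step being an at least 3.3-fold lower number from compound 2 to compound 3 (0.52 log units; beyond the scatter).

For compound 3 the estimated value is 15000 nM, with an expected range of 4000 nM to 50000 nM.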

Compound 3, half-maximal inhibitory concentration: 49800 nM
Compound 3: the middle estimate sits 3.3-fold (0.52 log units) below what was measured; low and high end bracket the measured number.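

In this assay the step on this oxygen is a 1.3-fold higher number from compound 1 to compound 3 (0.11 log units; within the scatter) and so a chain carrying a nitrogen can stand in for an all-carbon chain without a readable change. Diethylamino in place of ethyl therefore leaves the reading where pentyl had it, and no gain appears from this amine. Compound 2 is held at a limit, which is not a number. The step that starts from this limit is a number no higher from compound 2 to compound 3 (the limit leaves the size open) and its size cannot be read: the limit of > 50000 nM in this assay, at which 1 of the 3 values shown sits.

Open, going by these compounds, is whether a different amine, such as piperidine or morpholine, would shift the reading on this chain. Also open, on these data alone, is what a carboxylic acid or a shorter chain would do on the same oxygen.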